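Adding ethyl to a saturated chain in compound 2

A few compounds are considered here, and "the series" means these few. Any claim that something is new, unique, unknown or untested is made for them only; others in the source may bear on it.

Measured so far in an ADME assay on microsomes from liver (Mus musculus) for metabolic stability, tested at 5 uM; a lower number here means that the compound disappears faster, a higher number that the compound lasts longer:
- compound 1 `CCCCCCCCNc1ccc(C(=O)O)cc1S(=O)(=O)NC` gives 0.2 h
- compound 2 `CCCCCCNc1ccc(C(=O)O)cc1S(=O)(=O)N(C)C` gives 0.283 h

Among the compounds with values here, these are the only two numbers available, and compound 2 stands within the usual scatter of compound 1, so the pair cannot be told apart. Compound 3 `CCCCCCCCNc1ccc(C(=O)O)cc1S(=O)(=O)N(C)C` is compound 2 with ethyl in place of hydrogen on a saturated chain carbon, six bonds along the chain from a nitrogen on an aromatic ring and has not yet been measured. Within the data shown here, no measured pair isolates this change. The closest guide is compound 1, whose saturated chain matches that of compound 3 in length. In this assay compound 1 gives 0.2 h as its half-life. The expected change is a 1.4-fold lower number from compound 2 to compound 3 (0.15 log units; within the scatter) and this small downward step would not go beyond the scatter. For compound 3 the estimated half-life is 0.2 h with an expected range of 0.1 h to 0.35 h for this measurement.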

Compound 3, half-life: 0.217 h
Compound 3: middle estimate off by 1.1-fold (0.04 log units), on the low side; measured number inside the range.
By their numbers in this assay, from the lowest: compounds 1, 3 and 2 (each within the scatter of the next).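

In this assay, ethyl in place of hydrogen on a saturated chain carbon, six bonds along the chain from a nitrogen on an aromatic ring, gives a 1.3-fold lower number from compound 2 to compound 3 (0.12 log units; within the scatter) and stays within the scatter, so the two chain lengths cannot be told apart in half-life. Methyl in place of hydrogen on a sulfonamide nitrogen, a change no earlier pair isolated, gives a 1.1-fold higher number from compound 1 to compound 3 (0.04 log units; within the scatter) and also stays within the scatter, so this second place shows no readable effect either. Nothing measured here offers an explanation for these two results.

Still open, going by these compounds, is whether a much longer chain, or a chain ending in a hydroxyl group or an amine, would shift the half-life beyond the scatter. Also open, on these data alone, is what a larger group on the sulfonamide nitrogen, such as a cyclopropyl ring, would do.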